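Series notes: ether to carbamate on the ring oxygen

The compounds below may be only part of what the source reports. "The series", "measured", "known", "first", "only" and "open" are said of these compounds alone.

Compound 2 `CC(C)=CCC1Cc2c(OCCCNC(=O)c3ccco3)cc(=O)n(CCCO)c2CC1(C)C` stands lowest of the two numbers in a functional assay on PANC-1 cells (Homo sapiens) for inhibition, read by MTT assay, with a stated time of 24 h, tested at 10 uM (a lower number here means less inhibition, a higher number more inhibition at the concentration tested (going by the name of the read-out)), at 2.1%; compound 1 `CC(C)=CCC1Cc2c(O)cc(=O)n(CCCO)c2CC1(C)C` gives 25.6% in this assay. Among the measured compounds shown here, the only measured step bearing on compound 3 `COc1cccc(NC(=O)Oc2cc(=O)n(CCCO)c3c2CC(CC=C(C)C)C(C)(C)C3)c1` is a number 23.5 percentage points lower from compound 1 to compound 2 (beyond the scatter), a modest drop on placing a group on the ring oxygen. Compound 3 differs from compound 2 by (3-methoxyphenyl)carbamoyl in place of 3-(((furan-2-yl)carbonyl)amino)propyl on an oxygen on an aromatic ring; it keeps a substituent on that oxygen, so no step beyond the scatter is expected, with a number 5.9 percentage points higher from compound 2 to compound 3 (within the scatter) as the estimated step. For compound 3 the expected value is 8%, in the range -6% to 24%.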

Compound 3, a percentage reported as inhibition, at one concentration (the size of the read-out at that concentration, not a potency): 16.2%
For compound 3 the middle estimate is 8.2 percentage points below the measured one; low and high end bracket the measured number.
By their numbers in this assay, from the lowest: compound 2; then compounds 3 and 1 (each within the scatter of the next).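

In this assay, the group on the ring oxygen sets the read-out even when two groups have the same heavy-atom count: replacing 3-(((furan-2-yl)carbonyl)amino)propyl with (3-methoxyphenyl)carbamoyl gives a number 14.1 percentage points higher from compound 2 to compound 3 (beyond the scatter). Substitution on this oxygen therefore need not separate a compound from the free hydroxyl parent, as a number 9.4 percentage points lower from compound 1 to compound 3 (within the scatter) shows. No available data account for either step.

On these data alone, the shared-atom-count swap changes the ring and the linkage together, so their separate contributions remain open. Also open, as far as these compounds go, is how an amine or a carboxylic acid on a longer chain at this oxygen would read out.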